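Cytotoxicity notes: from compound 2 to compound 4

The compounds below may be only part of what the source reports. "The series", "measured", "known", "first", "only" and "open" are said of these compounds alone.

- compound 1 `Cc1cccc(NC(=O)CSc2nc(-c3ccccc3)cc(-c3ccccc3)c2C#N)c1`: > 250000 nM (a limit of the assay)
- compound 2 `CC[C@H](C)[C@H](NC(=O)CSc1nc(-c2ccccc2)cc(-c2ccc(C)cc2)c1C#N)C(=O)OC`: 229000 nM
- compound 3 `COC(=O)C[C@H](NC(=O)[C@@H](NC(=O)CSc1nc(-c2ccccc2)cc(-c2ccc(C)cc2)c1C#N)C(C)C)C(=O)OC`: > 250000 nM (a limit of the assay)

Among the measured compounds shown here, in an ADME assay on HEK-293T cells (Homo sapiens) for cytotoxicity, read by MTT assay, with a stated time of 24 h (on this read-out lower numbers stand for higher toxicity in this test and higher numbers for lower toxicity in this test), compound 2 gives 229000 nM, the only exact number among the three. The other two results are recorded as the limit of > 250000 nM in this assay, at which 2 of the 3 values shown sit. Compound 4 `Cc1ccc(-c2cc(-c3ccccc3)nc(SCC(=O)O)c2C#N)cc1` is still unmeasured. It carries hydroxy in place of (1-(methoxycarbonyl)-2-methylbutyl)amino on a carbonyl carbon. No measured pair sizes this change, so the expectation in this assay is no shift beyond the scatter, resting only on compound 2 at 229000 nM. The expected 1.0-fold lower number from compound 2 to compound 4 (0.02 log units; within the scatter) is accordingly small. The estimated value for compound 4 is 220000 nM, with an expected range of 100000 nM to 400000 nM.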

Compound 4, half-maximal cytotoxic concentration: 218000 nM
Estimate against measurement, compound 4: 1.0-fold (0.00 log units) above, within the range that was stated.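

In this assay, this position now has its first readable step: a 1.1-fold lower number from compound 2 to compound 4 (0.02 log units; within the scatter). The (1-(methoxycarbonyl)-2-methylbutyl)amino group, with its 10 heavy atoms and 2 defined stereocentres, thus gives way to hydroxy on a carbonyl carbon with no shift beyond the scatter. Compound 1 and compound 3 add no number to this comparison: the limit of > 250000 nM in this assay, at which 2 of the 4 values shown sit.

On these data alone, what methoxy or a plain amino group on that carbonyl carbon would give stays open. So does the effect of any single change on the shared core.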